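The source may hold more compounds than are shown below. What is called first, only, known or untested is meant among the compounds shown, and "the series" means these compounds.

Measured compounds:
Compound 1, `C1CC23CCCC2(C1)CNC3`: in an ADME assay on MDCK cells (Canis lupus familiaris) for cytotoxicity, read by microscopy (on this read-out higher numbers stand for lower toxicity in this test and lower numbers for higher toxicity in this test), compound 1 gives > 100000 nM, which is a limit of the test and not a number.
Compound 2, `N=C(N)N1CC23CCCC2(CCC3)C1`: in this assay compound 2 gives 54000 nM.
Compound 3, `C=C1CC23CNCC2(C1)CC(=C)C3`: in this assay compound 3 gives > 100000 nM, again a limit of the test.

Among the measured compounds shown here, the one measured step here runs from compound 1 to compound 2, where a group of 3 heavy atoms (1 carbon, 2 nitrogen; no ring) in place of a hydrogen atom, on an amine nitrogen in a ring is made and gives an at least 1.8-fold lower number from compound 1 to compound 2 (0.26 log units; that floor lies within the scatter). Since the limit of > 100000 nM in this assay, at which 2 of the 3 values shown sit, marks where the starting value sits, the true size of that step is not pinned down. Compound 3 shares with compound 1 only a general likeness; the difference between the two cores is not broken down here.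

Compound 4, `C=C1CC23CC(=C)CC2(C1)CN(C(=N)N)C3`, has not yet been tested. It stands to compound 3 as compound 2 stands to compound 1: a group of 3 heavy atoms (1 carbon, 2 nitrogen; no ring) in place of a hydrogen atom, on an amine nitrogen in a ring, and the place is described in the same words for both pairs, so it is the same change. In this assay the author expects an at least 1.6-fold lower number from compound 3 to compound 4 (0.22 log units; that floor lies within the scatter) for compound 4, resting on the step from compound 1 to compound 2, with the value of compound 3 likewise a limit so that the estimate is loosely held. For compound 4 the expected value is 60000 nM, between 25000 nM and 150000 nM.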

Compound 4, minimum cytotoxic concentration: 16000 nM
Beside the measured number, compound 4's estimate is 3.8-fold (0.57 log units) above it; measured number outside the range, below it.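

In this assay the change has now been read on a second core, and it gives an at least 6.2-fold lower number from compound 3 to compound 4 (0.79 log units; beyond the scatter), so here the floor of the step alone clears the usual scatter. Set beside the earlier step, this shows a lower number on both cores, but only the second floor lies beyond the scatter, and it does not show that the change has a larger effect on one core than on the other: the same change on two cores in this assay, an at least 1.8-fold lower number (0.26 log units; that floor lies within the scatter) from compound 1 to compound 2 and an at least 6.2-fold lower number (0.79 log units; beyond the scatter) from compound 3 to compound 4; the limit leaves it open whether they differ. As far as these compounds go, each step starts from a limit of the test, so each gives only a floor, the true size of the change stays unknown on either core, and no size can yet be carried from one core to the other: the limit of > 100000 nM in this assay, at which 2 of the 4 values shown sit.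

The compounds shown leave open whether a methyl group, an acetyl group or a longer chain on the same ring nitrogen would also give a lower number in this assay, or whether this is seen only with the group of carbon and nitrogen atoms used here. They also leave open how the change would read on a core whose parent amine gives a measured number rather than a limit, which is the comparison that could fix the size of the step.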